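The source may report more compounds than this note shows. Statements on the series, on what has been measured and on what is new or still open speak of the compounds shown alone.

Working notes on the series. The shared core is carried by compound 1 `CNC(=O)N1CCCc2ccc(NC(=O)c3ccc(-c4cc[nH]n4)cc3)cc21`, compound 2 `CNC(=O)N1CCCc2ccc(NC(=O)c3ccc(-c4ccn(C)n4)cc3)cc21` and compound 3 `CNC(=O)N1CCCc2ccc(NC(=O)c3ccc(-c4cnn(C)c4)cc3)cc21`. In a functional assay on MV4-11 cells (Homo sapiens) for antiproliferative activity, with a stated time of 6 days, tested at 6.25 uM (on this read-out higher numbers stand for a stronger effect at the one concentration tested and lower numbers for a weaker effect), compound 1 gives 99.1%. Compound 2 gives 97% and compound 3 gives 94.4% in this assay. Compound 3 holds the smallest of the three numbers, but the gaps are a number 4.7 percentage points lower from compound 1 to compound 3 (within the scatter) and a number 2.6 percentage points lower from compound 2 to compound 3 (within the scatter), and neither separates it from the others.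

Compound 4 `CNC(=O)N1CCCc2ccc(NC(=O)c3ccc(-c4ccn(C(C)=O)n4)cc3)cc21` is not yet measured in this assay. It differs from compound 3 by 1-acetyl-1H-pyrazol-3-yl in place of 1-methyl-1H-pyrazol-4-yl on an aromatic carbon. Within the data shown here, two measured steps bear on this: a methyl in place of hydrogen on an aromatic nitrogen gave a number 2.1 percentage points lower from compound 1 to compound 2 (within the scatter), and the shift between the two methylpyrazolyl attachment points gave a number 2.6 percentage points lower from compound 2 to compound 3 (within the scatter). Among the measured compounds shown here, nothing among the measured compounds carries an acetyl on the aromatic nitrogen, so that part of the change is untested. Since every change made so far at this position stayed within the scatter, the step of a number 0.4 percentage points lower from compound 3 to compound 4 (within the scatter) is expected to stay within the scatter as well. Compound 4 is therefore estimated at 94%, between 82% and 99%.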

Compound 4, a percentage reported as inhibition, at one concentration (the size of the read-out at that concentration, not a potency): 91.4%
Beside the measured number, compound 4's estimate is 2.6 percentage points above it, within the range that was stated.
By their numbers in this assay, from the lowest: compounds 4, 3, 2 and 1 (each within the scatter of the next).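

An acetyl on the aromatic nitrogen, a substituent larger than hydrogen or methyl, still leaves the read-out in this assay within the scatter of the compounds with those smaller groups (a number 7.7 percentage points lower from compound 1 to compound 4 (within the scatter)) and (a number 5.6 percentage points lower from compound 2 to compound 4 (within the scatter)). The comparison with compound 3 gives the same picture (a number 3 percentage points lower from compound 3 to compound 4 (within the scatter)), although this step changes both the substituent and the attachment point, so it cannot assign any share to either change. Across compounds 1, 2 and 4, this nitrogen therefore accepts hydrogen, methyl and acetyl with no separable difference at the single concentration tested, and no available evidence accounts for this.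

The compounds shown leave open whether a longer chain, an amine or a carboxylic acid on that nitrogen would stay within the scatter. They also leave open whether hydrogen, methyl and acetyl would separate into a stronger or weaker effect at other concentrations.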